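The source may hold more compounds than are shown below. What is called first, only, known or untested is meant among the compounds shown, and "the series" means these compounds.

Compound 1 `CN1CCN(c2ccc(Nc3ncc4c(n3)N(C3CCCC3)CC(=O)N4)nc2)CC1` is known only as a limit: in a functional assay on MDA-MB-231 cells (Homo sapiens) for inhibition, read by MTT assay, with a stated time of 48 h (on this read-out higher numbers stand for weaker inhibition and lower numbers for stronger inhibition), compound 1 gives > 30000 nM, which is a limit of the assay and not a number. Compound 2 `CC1CCN(c2ccc(Nc3ncc4c(n3)N(C3CCCC3)CC(=O)N4)nc2)CC1` gives > 30000 nM in this assay, also a limit. The step that the two limits leave unreadable from compound 1 to compound 2 is therefore unreadable, as the limit of > 30000 nM in this assay, at which 2 of the 2 values shown sit, shows. Compound 3 `CCN1C(=O)CN(C2CCCC2)c2nc(Nc3ccc(N4CCN(C)CC4)cn3)ncc21` differs from compound 1 by ethyl in place of hydrogen on an amide-type nitrogen in a ring. Within the data shown here, no measured step touches this position, so the expected size of a number no higher from compound 1 to compound 3 (the limit leaves the size open) rests on no measured pair at all. Compound 3 is expected to give about 30000 nM in this assay, within a range from 5000 nM to 100000 nM.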

Compound 3, half-maximal inhibitory concentration: 24100 nM
Beside the measured number, compound 3's estimate is 1.2-fold (0.10 log units) above it, within the range that was stated.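

Ethyl in place of hydrogen on the amide-type nitrogen in a ring gives the first value in this assay that is a number and not a limit, with an at least 1.2-fold lower number from compound 1 to compound 3 (0.09 log units; that floor lies within the scatter). This position can therefore carry ethyl and still give a readable value. From the compounds shown here alone, the true size of the step stays open because compound 1 is known only as a limit: the limit of > 30000 nM in this assay, at which 2 of the 3 values shown sit.

Going by these compounds, whether a longer chain such as propyl, or a chain ending in an amine or a carboxylic acid, would move the number beyond the scatter remains open. So does whether ethyl would act the same way alongside the 4-methylpiperidin-1-yl group of compound 2.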